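Working notes: two measured analogues, one estimate at the same position

The source may hold more compounds than are shown below. What is called first, only, known or untested is meant among the compounds shown, and "the series" means these compounds.

compound 1: `CCOC(=O)C1=C(NN=C(C(C)=O)C(C)=O)Nc2[nH]nc(C)c2C1c1ccc(N(C)C)cc1` — 8480 nM
compound 2: `CCOC(=O)C1=C(NN=C(C#N)C#N)Nc2[nH]nc(C)c2C1c1ccc(N(C)C)cc1` — 13700 nM

Among the compounds with values here, in a functional assay on HepG2 cells (Homo sapiens) for inhibition, read by MTT assay, with a stated time of 48 h (on this read-out lower numbers stand for stronger inhibition and higher numbers for weaker inhibition), compound 1 gives 8480 nM, the lower of the two numbers so far, though the gap to compound 2 is within the scatter. Compound 2 gives 13700 nM; the step is a 1.6-fold higher number from compound 1 to compound 2 (0.21 log units; within the scatter), and it replaces the group on the amine nitrogen with a smaller, ring-free one.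

Compound 3 `CCOC(=O)C1=C(N/C=N/c2ccc(C)cc2)Nc2[nH]nc(C)c2C1c1ccc(N(C)C)cc1` changes the same position in compound 1: a group of 9 heavy atoms (8 carbon, 1 nitrogen; one six-membered aromatic ring of carbon only) in place of a group of 8 heavy atoms (5 carbon, 1 nitrogen, 2 oxygen; no ring), on an amine nitrogen. Within the data shown here, the one measured step at this position, from compound 1 to compound 2, stayed within the scatter, so no step beyond the scatter is expected here either, in either direction; the expected step is a 1.1-fold higher number from compound 1 to compound 3 (0.03 log units; within the scatter). Among the measured compounds shown here, for compound 3 the estimated value in this assay is 9000 nM, with a range from 3000 nM to 30000 nM; the range is kept wide because the single comparison a 1.6-fold higher number from compound 1 to compound 2 (0.21 log units; within the scatter) gives little to go on for a ring-bearing replacement.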

Compound 3, half-maximal inhibitory concentration: 44400 nM
Estimate against measurement, compound 3: 4.9-fold (0.69 log units) below, and the stated range ends below it.
By their numbers in this assay, from the lowest: compounds 1 and 2 (each within the scatter of the next); then compound 3.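

In this assay the group on the amine nitrogen proves able to move the number beyond the scatter, in both available comparisons (a 5.2-fold higher number from compound 1 to compound 3 (0.72 log units; beyond the scatter); a 3.2-fold higher number from compound 2 to compound 3 (0.51 log units; beyond the scatter)), which the earlier step alone did not show. Compound 3 is the only one of the three whose group carries a six-membered aromatic ring of carbon only, and it stands apart from the ring-free groups of compounds 1 and 2, though this single compound cannot separate the ring from the other differences between the groups. No measurement available here explains the shift.

On these data alone, it remains open whether the higher number goes with the aromatic ring as such, which a cyclohexyl group or a pyridine ring at this position would test. As far as these compounds go, it also remains open whether any group here, such as a carboxylic acid or a longer alkyl chain, gives a number lower than those of compounds 1 and 2.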